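Fluoro-to-methyl swap on a nitro sulfonamide series

A few compounds are considered here, and "the series" means these few. Any claim that something is new, unique, unknown or untested is made for them only; others in the source may bear on it.

Measured so far:
compound 1, `Cc1ccc(NS(=O)(=O)c2ccc(F)cc2)c([N+](=O)[O-])c1`, 2.34 nM
compound 2, `Cc1ccc(NC(=O)c2ccc(C)cc2)cc1`, 55000 nM
compound 3, `Cc1ccc(CNc2ccc(C)cc2)cc1`, 19100 nM

Three compounds have numbers in a functional assay on LNCaP cells (Homo sapiens) for cytotoxicity, read by MTT assay, with a stated time of 5 days; on this read-out lower numbers stand for stronger inhibition of growth and higher numbers for weaker inhibition of growth. Compound 1 stands lowest of the three; compound 3 sits nearest to it, yet far beyond the scatter, and compound 2 sits furthest, also beyond the scatter. For the measured compounds named here, compounds 2 and 3 share neither the sulfonyl linkage nor the nitro group of compound 1, so no single-change step joins any pair here; all that can be said is what their numbers show.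

Compound 4, `Cc1ccc(S(=O)(=O)Nc2ccc(C)cc2[N+](=O)[O-])cc1`, is not yet measured. It differs from compound 1 in one place: methyl in place of fluoro on an aromatic carbon. The change sits on an aromatic carbon of a six-membered aromatic ring of carbon only, para to a large group; the sulfonamide and the nitro group of compound 1 are kept.

Going by the values given here, no measured pair shows this change, so there is nothing to scale a step from. On this read-out the step from compound 1 to compound 4 is expected to be a 1.5-fold higher number from compound 1 to compound 4 (0.17 log units; within the scatter), which amounts to no move beyond the scatter. Compound 4 is therefore estimated at 3.5 nM, within 1 nM to 12 nM.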

Compound 4, concentration for 50% growth inhibition: 39800 nM
Compound 4: middle estimate off by 11000-fold (4.06 log units), on the low side; measured number outside the range, above it.
By their numbers in this assay, from the lowest: compound 1; then compound 3; then compounds 4 and 2 (each within the scatter of the next).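

In this assay, the change from 4-fluorophenyl to 4-methylphenyl gives a 17000-fold higher number from compound 1 to compound 4 (4.23 log units; beyond the scatter), a large step beyond the scatter, although one heavy atom replaces one heavy atom and the counted hydrogen-bond donors, acceptors and net charge stay the same. The sulfonamide and nitro group are kept in compound 4, so these two groups alone do not secure the low number of compound 1, and the substituent at this place on the aromatic carbon matters greatly. Nothing measured here accounts for the size of the step.

This single pair cannot show whether fluoro is specifically favoured or methyl specifically disfavoured at this place. Chloro, methoxy, an amine or an unsubstituted ring carbon would help separate those two readings.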